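Tertiary cyclic amide variant of the fluoroindanylidene acetamide

A few compounds are considered here, and "the series" means these few. Any claim that something is new, unique, unknown or untested is made for them only; others in the source may bear on it.

Compound 2 `CCNC(=O)/C=C1\CCc2ccc(F)cc21` stands highest of the two numbers in a functional assay on the whole organism with Rattus norvegicus as the target, at a dose of 20 mg/kg by the oral route (on this read-out lower numbers stand for less inhibition and higher numbers for more inhibition at the one dose given (going by the name of the read-out)), giving 63%, while compound 1 `O=C(/C=C1\CCc2ccc(F)cc21)NCC1CC1` gives 21%; the step of a number 42 percentage points higher from compound 1 to compound 2 (beyond the scatter) is large. Compound 3 `O=C(/C=C1\CCc2ccc(F)cc21)N1CCCC1` differs from compound 2 by pyrrolidin-1-yl in place of ethylamino on a carbonyl carbon. Among the measured compounds shown here, the one measured step changed only the substituent on the amide nitrogen and kept the amide hydrogen, so it bears on this change only loosely; no measured step removes the hydrogen-bond donor. Given that, the expected step for compound 3 is a number 23 percentage points lower from compound 2 to compound 3 (beyond the scatter), a downward move with wide uncertainty. Compound 3 is estimated at 40%, within 10% to 70%.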

Compound 3, a percentage reported as inhibition, in the whole organism at one dose (the size of the read-out at that dose, not a potency): 18%
Compound 3: middle estimate off by 22 percentage points, on the high side; the measured number falls inside the stated range.
By their numbers in this assay, from the lowest: compounds 3 and 1 (each within the scatter of the next); then compound 2.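

In this assay pyrrolidin-1-yl in place of ethylamino on a carbonyl carbon gives a number 45 percentage points lower from compound 2 to compound 3 (beyond the scatter) while pyrrolidin-1-yl in place of (cyclopropylmethyl)amino gives a number 3 percentage points lower from compound 1 to compound 3 (within the scatter) at that same place. Among these three compounds, compound 2 alone stands apart, and the pyrrolidin-1-yl amide without a hydrogen-bond donor sits level with the (cyclopropylmethyl)amino amide that keeps one. No measurement here gives a reason for these steps.

Going by these compounds, it remains open whether the lower number of compound 3 follows the missing donor or the ring. Dimethylamino on the same carbonyl carbon would separate these two changes.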